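Compound 4: one group exchanged on compound 1

A few compounds are considered here, and "the series" means these few. Any claim that something is new, unique, unknown or untested is made for them only; others in the source may bear on it.

In an ADME assay on HEK-293T cells (Homo sapiens) for cytotoxicity, read by CCK-8 assay, with a stated time of 48 h (on this read-out higher numbers stand for weaker inhibition and lower numbers for stronger inhibition), compound 1 (`COc1ccc(Oc2ccccc2-c2ccsc2S(=O)(=O)N2CCN(C(=S)Nc3ccc([N+](=O)[O-])cc3)CC2)cc1OC`) reaches only a limit, > 20000 nM. Compound 3 (`COc1ccc(Oc2ccc([N+](=O)[O-])cc2-c2ccsc2S(=O)(=O)N2CCN(C(=S)Nc3ccc([N+](=O)[O-])cc3)CC2)cc1OC`) also ends at a limit, > 50000 nM. Compound 2 (`O=C(NCCNS(=O)(=O)c1sccc1-c1ccccc1Oc1ccc(O)c(O)c1)Nc1cc(Cl)cc(Cl)c1`), which differs from both in more than one place, gives a number, 10700 nM. Compound 4 (`COc1ccc(Oc2ccccc2-c2ccsc2S(=O)(=O)N2CCN(C(=O)Nc3cccc([N+](=O)[O-])c3)CC2)cc1OC`) departs from compound 1 in a single group: a group of 12 heavy atoms (7 carbon, 2 nitrogen, 3 oxygen; one six-membered aromatic ring of carbon only) in place of a group of 12 heavy atoms (7 carbon, 2 nitrogen, 2 oxygen, 1 sulfur; one six-membered aromatic ring of carbon only), on an amine nitrogen in a ring. Here (3-nitrophenyl)carbamoyl enters on an amine nitrogen in a ring. Going by the values given here, the only measured step, a step that the two limits leave unreadable from compound 1 to compound 3, is nitro in place of hydrogen on an aromatic carbon and offers no size to carry over. The expected step, a step that the limit leaves unreadable from compound 1 to compound 4, is therefore estimated to stay within the scatter, in no particular direction. Compound 4 is expected at 25000 nM, with an estimated range of 10000 nM to 60000 nM.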

Compound 4, half-maximal inhibitory concentration: > 20000 nM
Compound 4 ended at the assay's limit; the forecaster's own chance of this, stated with the estimate: 55%; the middle value is on the limit's open side.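

Going by these compounds alone, compound 1 and compound 4 both stop at a limit, so no step between them can be read: the limit of > 20000 nM in this assay, at which 2 of the 4 values shown sit. The compounds shown leave open whether (3-nitrophenyl)carbamoyl on the amine nitrogen changes the value in this assay at all.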